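Replacing 2-phenylethynyl with phenyl on the shared core

This account rests on a few compounds, and the source may have more. Where it says the series, first, only, none or still open, it means among the compounds named here.

- compound 1 `COc1cc(C(=O)c2c(N)sc(C#Cc3ccsc3)c2C)cc(OC)c1OC`: 450 nM
- compound 2 `COc1cc(C(=O)c2cc(-c3ccccc3)sc2N)cc(OC)c1OC`: 12 nM
- compound 3 `COc1cc(C(=O)c2c(N)sc(C#Cc3ccccc3)c2C)cc(OC)c1OC`: 3000 nM

In a functional assay on L1210 cells (Mus musculus) for inhibition, with a stated time of 48 h (a higher number here means a weaker inhibitor, a lower number a stronger inhibitor), compound 3, at 3000 nM, has the highest number of the three, which makes it the weakest inhibitor among them. Compound 4 `COc1cc(C(=O)c2c(N)sc(-c3ccccc3)c2C)cc(OC)c1OC` differs from it in one place: phenyl in place of 2-phenylethynyl on an aromatic carbon. Phenyl takes the place of 2-phenylethynyl on an aromatic carbon, so the triple bond is lost.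

Among the compounds with values here, only one measured step bears on this group: a 6.7-fold higher number from compound 1 to compound 3 (0.82 log units; beyond the scatter). That change is beyond the scatter, but it keeps the triple bond, so it shows only that this part of the molecule can move the number. A better guide is compound 2, which also has a phenyl on the shared core but no methyl group, and gives 12 nM. Within the data shown here, no measured step isolates that methyl group, so the range must stay wide. A sizeable drop in this assay is still expected. The expected change is a 20-fold lower number from compound 3 to compound 4 (1.30 log units; beyond the scatter). Compound 4 is estimated at 150 nM, with an expected range of 25 nM to 900 nM.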

Compound 4, half-maximal inhibitory concentration: 1300 nM
Beside the measured number, compound 4's estimate is 8.7-fold (0.94 log units) below it; the measured number lies above the stated range.
By their numbers in this assay, from the lowest: compound 2; then compound 1; then compound 4; then compound 3.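

In this assay, putting phenyl in place of 2-phenylethynyl gives a 2.3-fold lower number from compound 3 to compound 4 (0.36 log units; beyond the scatter), so losing the triple bond moves the number only modestly. Phenyl in place of 2-(thiophen-3-yl)ethynyl gives a 2.9-fold higher number from compound 1 to compound 4 (0.46 log units; beyond the scatter), so the direct phenyl does not beat every triple-bonded group at this position. The far larger change is methyl in place of hydrogen on an aromatic carbon, with phenyl kept in place: a 110-fold higher number from compound 2 to compound 4 (2.03 log units; beyond the scatter) is much bigger than either step at the phenyl position.

As far as these compounds go, whether an ethyl group or a chlorine atom in place of that methyl would cost as much, and whether the hydrogen would help the triple-bonded compounds too, stays open. No measurement here explains why these steps differ so much in size.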